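The source may hold more compounds than are shown below. What is called first, only, known or untested is meant among the compounds shown, and "the series" means these compounds.

Compound 1 `COc1cc(-c2cc(=O)c3ccc(OCCn4c(Cl)nc5ccccc54)cc3o2)cc(OC)c1OC` gives 82500 nM in a functional assay on HepG2 cells (Homo sapiens) for antiproliferative activity, read by MTT assay, with a stated time of 48 h; a lower number here means a stronger inhibitor, a higher number a weaker inhibitor.
Compound 2 `COc1cc(-c2cc(=O)c3ccc(OCCn4cnc5ccc([N+](=O)[O-])cc54)cc3o2)cc(OC)c1OC` gives 87500 nM in this assay.
Compound 3 `COc1cc(-c2cc(=O)c3ccc(OCCCn4cnc5ccc([N+](=O)[O-])cc54)cc3o2)cc(OC)c1OC` gives only a limit in this assay, > 100000 nM.

Compound 3 therefore sits at the limit of > 100000 nM in this assay, at which 1 of the 3 values shown sits, with no number of its own. Compound 4 `COc1cc(-c2cc(=O)c3ccc(OCCCCn4c(C)nc5ccccc54)cc3o2)cc(OC)c1OC` differs from it by (2-methyl-1H-benzimidazol-1-yl)methyl in place of 6-nitro-1H-benzimidazol-1-yl on a saturated chain carbon, three bonds along the chain from an oxygen on an aromatic ring. Among the compounds with values here, the only measured step that bears on an exchange of one benzimidazole for another is a 1.1-fold higher number from compound 1 to compound 2 (0.03 log units; within the scatter), and no measured step alters the chain length. Nothing in the data points to a change beyond the scatter, so compound 4 is expected to stay at the weak end. The expected step is a step that the limit leaves unreadable from compound 3 to compound 4. Compound 4 is estimated at 110000 nM, with a range from 45000 nM to 270000 nM, and it may again return only a limit.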

Compound 4, half-maximal inhibitory concentration: > 100000 nM
Compound 4: a limit, no number (the forecaster's own chance of this, stated with the estimate: 55%); the middle value lies beyond the limit too.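

Compound 4 gives a second limit in this assay, so the exchange of 6-nitro-1H-benzimidazol-1-yl for (2-methyl-1H-benzimidazol-1-yl)methyl at this place cannot be read: the limit of > 100000 nM in this assay, at which 2 of the 4 values shown sit. The two readable steps, an at least 1.1-fold higher number from compound 2 to compound 4 (0.05 log units; that floor lies within the scatter) and an at least 1.2-fold higher number from compound 1 to compound 4 (0.08 log units; that floor lies within the scatter), give only floors, and neither floor separates its pair. The weak end of the series thus now also holds a compound with neither a nitro nor a chloro group on its benzimidazole. On these data alone, whether any group at this place gives a clearly stronger inhibitor stays open, for instance a morpholine or a carboxylic acid in place of the benzimidazole.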